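A few compounds are considered here, and "the series" means these few. Any claim that something is new, unique, unknown or untested is made for them only; others in the source may bear on it.

Compound 2 `CCCc1cc(N)c2cc(NC(=O)/C=C/c3ccc(N)cc3)ccc2n1` gives 190 nM in an assay on isolated protein for displacement of a labelled ligand from melanin-concentrating hormone receptor 1 (Homo sapiens) (on this read-out lower numbers stand for stronger inhibition and higher numbers for weaker inhibition), the highest of the three numbers measured, so it is the least potent compound here. Compound 4 `CCCc1cc(N)c2cc(NC(=O)/C=C/c3ccc(Cl)cc3)ccc2n1` differs from it in one place: chloro in place of amino on an aromatic carbon. Within the data shown here, no measured step covers this exact change. Among the measured compounds shown here, the only measured step, a 6.7-fold higher number from compound 1 to compound 3 (0.82 log units; beyond the scatter), concerns a different group on the shared core. Compound 1 `CC(C)(C)c1cc(N)c2cc(NC(=O)/C=C/c3ccc(C(F)(F)F)cc3)ccc2n1` gives 0.3 nM and compound 3 `Nc1cc(C2CCC2)nc2ccc(NC(=O)/C=C/c3ccc(C(F)(F)F)cc3)cc12` gives 2 nM; both carry trifluoromethyl where compound 2 carries amino, and their numbers lie far below that of compound 2, though these are not single-step comparisons. Compound 4 is therefore expected to show a large drop in this assay, a 38-fold lower number from compound 2 to compound 4 (1.58 log units; beyond the scatter), with an estimated 5 nM and a range from 1 nM to 30 nM.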

Compound 4, half-maximal inhibitory concentration: 6 nM
Compound 4: middle estimate off by 1.2-fold (0.08 log units), on the low side; low and high end bracket the measured number.
By their numbers in this assay, from the lowest: compound 1; then compound 3; then compound 4; then compound 2.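

In this assay, replacing 4-aminophenyl with 4-chlorophenyl, with nothing else changed, gives a 32-fold lower number from compound 2 to compound 4 (1.50 log units; beyond the scatter). Among these compounds, this is the first single-place comparison at this position, para to a large group, and it shows that the group here strongly affects the number. Chloro also lacks the hydrogen-bond donor and acceptor that amino has, but no measurement here explains the size of this step.

On these data alone, whether a methoxy group, a carboxylic acid or a longer chain at this position would give a lower or higher number stays open. As far as these compounds go, it is also open whether the same swap would give a similar step with tert-butyl or cyclobutyl on the shared core.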